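Lengthening the chain of compound 2

A few compounds are considered here, and "the series" means these few. Any claim that something is new, unique, unknown or untested is made for them only; others in the source may bear on it.

In a functional assay on CNE-2 cells (Homo sapiens) for inhibition, read by MTT assay, with a stated time of 72 h (on this read-out higher numbers stand for weaker inhibition and lower numbers for stronger inhibition), compound 2 (`Nc1nc2cc(-c3nn(CCCC(=O)NO)c4ncnc(N)c34)ccc2o1`) stands at > 50000 nM as a limit of the assay, not a number. Compound 1 (`Nc1ncnc2c1c(-c1cnc3[nH]ccc3c1)nn2CC(=O)NO`) is likewise only a limit, at > 150000 nM in this assay as well. Compound 3 (`Nc1ncnc2c1c(-c1cnc3[nH]ccc3c1)nn2CCCCCCC(=O)NO`) does give a number, 19500 nM in this assay again.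

Compound 4 (`Nc1nc2cc(-c3nn(CCCCCCCCC(=O)NO)c4ncnc(N)c34)ccc2o1`) brings 5-(hydroxycarbamoyl)pentyl in place of hydroxycarbamoyl on a saturated chain carbon, three bonds along the chain from an aromatic nitrogen and so places 5-(hydroxycarbamoyl)pentyl in place of hydroxycarbamoyl on a saturated chain carbon, three bonds along the chain from an aromatic nitrogen. Going by the values given here, one measured step bears on this, and it ends at compound 3: the same exchange on a different core, on a chain carbon bound to an aromatic nitrogen, gave an at least 7.6-fold lower number from compound 1 to compound 3 (0.88 log units; beyond the scatter) and lies beyond the scatter, so a lower number is expected for compound 4 too. Among the compounds with values here, only this one pair supports that expectation. The expected size is an at least 6.2-fold lower number from compound 2 to compound 4 (0.79 log units; beyond the scatter) by estimate. For compound 4 the estimated value is 8000 nM with an expected range from 1000 nM to 40000 nM in this measurement.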

Compound 4, half-maximal inhibitory concentration: 3240 nM
Estimate against measurement, compound 4: 2.5-fold (0.39 log units) above; the range from low to high includes it.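

At this place, on a saturated chain carbon, three bonds along the chain from an aromatic nitrogen, 5-(hydroxycarbamoyl)pentyl in place of hydroxycarbamoyl turns a limit into a number in this assay, with an at least 15-fold lower number from compound 2 to compound 4 (1.18 log units; beyond the scatter). The change has now lowered the number on two cores, where a single pair stood before: the same change on two cores in this assay, an at least 7.6-fold lower number (0.88 log units; beyond the scatter) from compound 1 to compound 3 and an at least 15-fold lower number (1.18 log units; beyond the scatter) from compound 2 to compound 4; the limit leaves it open whether they differ

The value of compound 2 is a limit and not a number, so the full size of this step stays unknown: the limit of > 50000 nM in this assay, at which 1 of the 4 values shown sits.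

The compounds shown leave open how the number moves with a chain of intermediate length, or with a longer chain than 5-(hydroxycarbamoyl)pentyl, on either core. They also leave open whether a carboxylic acid at the chain end, in place of the hydroxycarbamoyl group, would give a number in this assay.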